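Cytotoxicity notes: side-chain variation on the shared core

The compounds below may be only part of what the source reports. "The series", "measured", "known", "first", "only" and "open" are said of these compounds alone.

Compound 1 `O=C(OC[C@H]1CN(c2ccc(-n3cc(-c4ccccn4)cn3)c(F)c2)C(=O)O1)c1ccccc1` is screened for cytotoxicity in an ADME assay on L02 cells (Homo sapiens) for cytotoxicity, read by MTT assay, with a stated time of 48 h; a higher number here means a weaker inhibitor, a lower number a stronger inhibitor. In this assay compound 1 reaches only the assay limit > 400 ug/mL. Compound 2 `COC[C@H]1CN(c2ccc(-n3cc(-c4ccccn4)cn3)c(F)c2)C(=O)O1` likewise stops at the limit > 400 ug/mL in this assay. The step that the two limits leave unreadable from compound 1 to compound 2 is thus unreadable, and the limit of > 400 ug/mL in this assay, at which 2 of the 2 values shown sit, is all the measured pair shows. Compound 3 `NC(=O)[C@H]1CN(c2ccc(-n3cc(-c4ccccn4)cn3)c(F)c2)C(=O)O1` carries carbamoyl in place of (benzoyloxy)methyl on a saturated ring carbon. No readable step bears on this change. For compound 3 the step of a number no higher from compound 1 to compound 3 (the limit leaves the size open) is expected to stay within scatter, at the same limit. Compound 3 is estimated at 400 ug/mL, in the range 200 ug/mL to 800 ug/mL.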

Compound 3, half-maximal inhibitory concentration: 119 ug/mL
Estimate against measurement, compound 3: 3.4-fold (0.53 log units) above; the whole stated range lies above it.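

Carbamoyl on this saturated ring carbon gives the first readable step in this assay: there is an at least 3.3-fold lower number from compound 1 to compound 3 (0.52 log units; beyond the scatter), and an at least 3.3-fold lower number from compound 2 to compound 3 (0.52 log units; beyond the scatter). The position can therefore move the number, whether (benzoyloxy)methyl or methoxymethyl is the group replaced. Both steps give only a minimum size, as each starts from a limit: the limit of > 400 ug/mL in this assay, at which 2 of the 3 values shown sit.

From the compounds shown here alone, it remains open whether the lower number belongs to carbamoyl itself or would follow with other groups at this place. A carboxylic acid, an aminomethyl group or a longer chain ending in carbamoyl would separate these readings.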